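A few compounds are considered here, and "the series" means these few. Any claim that something is new, unique, unknown or untested is made for them only; others in the source may bear on it.

Measured in a functional assay on HeLa cells (Homo sapiens) for cytotoxicity, read by WST assay, with a stated time of 48 h; a lower number here means a stronger inhibitor, a higher number a weaker inhibitor:
- Compound 1 `COc1cc(C(c2ccc(O)c(OC)c2)[C@H](C)C(C)C)ccc1O`: 16000 nM
- Compound 2 `COc1cc(C(c2ccc(O)c(OC)c2)[C@@H](CO)C(C)C)ccc1O`: > 100000 nM, a limit of the assay
- Compound 3 `COc1cc(C(c2ccc(O)c(OC)c2)[C@H](CF)C(C)C)ccc1O`: 19000 nM

Compound 3, at 19000 nM, stands level with compound 1 within the scatter, as a 1.2-fold higher number from compound 1 to compound 3 (0.07 log units; within the scatter) shows. Compound 2 gives only a limit, > 100000 nM.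

The next compound, compound 4 `COc1cc(C(c2ccc(O)c(OC)c2)[C@@H](C)[C@H](C)CO)ccc1O`, keeps the shared core and replaces the side chain: 2-(hydroxymethyl)-1-methylpropyl in place of 1-(fluoromethyl)-2-methylpropyl on a saturated chain carbon bound to two aromatic carbons. It carries 2-(hydroxymethyl)-1-methylpropyl in place of 1-(fluoromethyl)-2-methylpropyl on a saturated chain carbon bound to two aromatic carbons.

The closest guide is compound 2, which also carries a hydroxymethyl group, though on a differently built chain. Two measured steps involve it: an at least 6.2-fold higher number from compound 1 to compound 2 (0.79 log units; beyond the scatter), and an at least 5.2-fold lower number from compound 2 to compound 3 (0.72 log units; beyond the scatter). Both sizes are bounds only, set by the limit of > 100000 nM in this assay, at which 1 of the 3 values shown sits. Compound 4 therefore is expected to give a higher number than compound 3 in this assay, by a modest step beyond the scatter, although the different chain makes a direct transfer uncertain. The expected step is a 2.6-fold higher number from compound 3 to compound 4 (0.42 log units; beyond the scatter). For compound 4 the estimated value is 50000 nM, with an expected range of 18000 nM to 100000 nM.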

Compound 4, half-maximal inhibitory concentration: > 100000 nM
Compound 4 was reported as a limit; the forecaster's own chance of this, stated with the estimate: 40%; middle value at least 2.0-fold (0.30 log units) away from the limit.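

In this assay, compound 4 gives > 100000 nM, which is a limit of the assay and not a number. On this saturated chain carbon bound to two aromatic carbons, a second, differently built hydroxymethyl chain therefore also ends at the limit, and it stands clearly apart from the two chains without a hydroxymethyl group: an at least 5.2-fold higher number from compound 3 to compound 4 (0.72 log units; beyond the scatter), and an at least 6.2-fold higher number from compound 1 to compound 4 (0.79 log units; beyond the scatter). The earlier compounds showed this for only one chain, but compound 2 and compound 4 cannot be ranked against each other, and the step between them cannot be read, because of where both values stand: the limit of > 100000 nM in this assay, at which 2 of the 4 values shown sit.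

The compounds shown leave open how far apart the 1-(hydroxymethyl)-2-methylpropyl and 2-(hydroxymethyl)-1-methylpropyl chains really lie, so it remains unsettled whether the placing of the hydroxymethyl group on the chain matters at all. They also leave open whether an aminomethyl or a methoxymethyl group in that place would follow the fluoromethyl group of compound 3 or the hydroxymethyl group of compound 2 and compound 4.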